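An Ester Returns on the Oxygen of the Shared Core

A few compounds are considered here, and "the series" means these few. Any claim that something is new, unique, unknown or untested is made for them only; others in the source may bear on it.

compound 1 `CC(C)=CC[C@@H](OC(=O)c1ccco1)C1=CC(=O)c2c(O)ccc(O)c2C1=O`: > 100000 nM
compound 2 `CC(=O)OC(C)CO[C@H](CC=C(C)C)C1=CC(=O)c2c(O)ccc(O)c2C1=O`: 16600 nM

In a functional assay on DU-145 cells (Homo sapiens) for cytotoxicity, read by MTT assay (on this read-out higher numbers stand for weaker inhibition and lower numbers for stronger inhibition), compound 2 gives 16600 nM, the only number shown. Compound 1 gives only a limit, > 100000 nM, which is the limit of > 100000 nM in this assay, at which 1 of the 2 values shown sits. Among the measured compounds shown here, the single measured step, an at least 6.0-fold lower number from compound 1 to compound 2 (0.77 log units; beyond the scatter), ran from that limit to the number. Compound 3 `CCC(O)(CC)CC(=O)O[C@H](CC=C(C)C)C1=CC(=O)c2c(O)ccc(O)c2C1=O` differs from compound 2 by (2-ethyl-2-hydroxybutyl)carbonyl in place of 2-acetoxypropyl on an oxygen on a saturated carbon. For the measured compounds named here, as in compound 1, an ester stands again on that oxygen, so a step back toward weaker inhibition is expected, though the entering group is not the one compound 1 carried. The estimated step is a 2.4-fold higher number from compound 2 to compound 3 (0.38 log units; beyond the scatter). Compound 3 is expected at 40000 nM, between 10000 nM and 150000 nM.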

Compound 3, half-maximal inhibitory concentration: 67000 nM
The estimate for compound 3 lay 1.7-fold (0.22 log units) below the measured number; measured number inside the range.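

In this assay, replacing 2-acetoxypropyl with (2-ethyl-2-hydroxybutyl)carbonyl gives a 4.0-fold higher number from compound 2 to compound 3 (0.61 log units; beyond the scatter), so a second ester on this oxygen, with a different acyl group from that of compound 1, also stands on the weaker side of compound 2. The exchange between the two esters, an at least 1.4-fold lower number from compound 1 to compound 3 (0.17 log units; that floor lies within the scatter), gives only a floor. Compound 1 stands at a limit and not at a number: the limit of > 100000 nM in this assay, at which 1 of the 3 values shown sits.

From the compounds shown here alone, it remains open whether the stronger inhibition of compound 2 depends on its acetoxy group or on the chain that carries it. A plain propyl chain or an aminopropyl chain on this oxygen would bear on that question.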